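The source may hold more compounds than are shown below. What is called first, only, known or untested is meant among the compounds shown, and "the series" means these compounds.

In a functional assay on MKN-45 cells (Homo sapiens) for cytotoxicity, read by MTT assay, with a stated time of 72 h (on this read-out lower numbers stand for stronger inhibition and higher numbers for weaker inhibition), compound 1 `COc1cc2c(Oc3ccc(NC(=O)c4cn(-c5ccccc5Cl)nn4)cc3F)ccnc2cc1OCCCN1CCC(C)CC1` gives 240 nM and compound 2 `COc1cc2c(Oc3ccc(NC(=O)c4cn(-c5ccccc5F)nn4)cc3F)ccnc2cc1OCCCN1CCC(C)CC1` gives 130 nM. Compound 3 `COc1cc2c(Oc3ccc(NC(=O)c4cn(-c5ccccc5C)nn4)cc3F)ccnc2cc1OCCCN1CCC(C)CC1` is reported in this assay as "not determined" (no result reported), so on the numbers shown it stands nowhere and serves only as the structural reference. Compound 4 `COc1cc2c(Oc3ccc(NC(=O)c4cn(-c5c(Cl)cccc5Cl)nn4)cc3F)ccnc2cc1OCCCN1CCC(C)CC1` differs from it by 2,6-dichlorophenyl in place of 2-methylphenyl on an aromatic nitrogen. Going by the values given here, no measured step covers this exchange directly; the only step available, a 1.8-fold lower number from compound 1 to compound 2 (0.27 log units; within the scatter), concerns a halogen swap on the same ring, and its size gives no sign of a large effect from changes at that ring. No step beyond the scatter is therefore expected in this assay for compound 4. Compound 4 is expected to give about 250 nM, with a range from 80 nM to 800 nM, which would sit near the value of compound 1 240 nM.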

Compound 4, half-maximal inhibitory concentration: 120 nM
Compound 4: middle estimate off by 2.1-fold (0.32 log units), on the high side, within the range that was stated.
By their numbers in this assay, from the lowest: compounds 4, 2 and 1 (each within the scatter of the next).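

In this assay the added chloro gives a 2.0-fold lower number from compound 1 to compound 4 (0.30 log units; within the scatter) and 2,6-dichlorophenyl in place of 2-fluorophenyl gives a 1.1-fold lower number from compound 2 to compound 4 (0.03 log units; within the scatter) so a second halogen on this ring, on the aromatic nitrogen, leaves compound 4 level with compound 1 and compound 2. Nothing available explains these numbers.

The steps from compound 3 cannot be read, as compound 3 has no number. As far as these compounds go, whether an amine or a carboxylic acid on this phenyl ring would bring a step beyond the scatter stays open.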